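The compounds below may be only part of what the source reports. "The series", "measured", "known", "first", "only" and "open" are said of these compounds alone.

Measured compounds:
Compound 1, `O=S(=O)(Nc1ccc(Cl)c(Cl)c1)c1ccc(-c2cnc(C3CC3)o2)cc1`, 62100 nM
Compound 2, `O=S(=O)(Nc1ccc(Cl)c(F)c1)c1ccc(-c2cnc(C3CC3)o2)cc1`, 63000 nM
Compound 3, `Cc1cc(Cl)cc(NS(=O)(=O)c2ccc(-c3cnc(C4CC4)o3)cc2)c1`, 7040 nM

The three compounds were tested in a functional assay on cells (leukaemia cell line, Homo sapiens) for inhibition, read by sulforhodamine B assay, with a stated time of 48 h; on this read-out lower numbers stand for stronger inhibition of growth and higher numbers for weaker inhibition of growth. Compound 1 and compound 2 share one core and differ only in the change (fluoro in place of chloro on an aromatic carbon); this change made a step of a 1.0-fold higher number from compound 1 to compound 2 (0.01 log units; within the scatter), so the two numbers cannot be told apart. Compound 3 carries a different aryl group on the sulfonamide nitrogen, and how the two cores differ is given by 3-chloro-5-methylphenyl in place of 3,4-dichlorophenyl on a sulfonamide nitrogen. That change gave a step of an 8.8-fold lower number from compound 1 to compound 3 (0.95 log units; beyond the scatter), and the corresponding step of an 8.9-fold lower number from compound 2 to compound 3 (0.95 log units; beyond the scatter) is of the same size, so compound 3 gives the lowest number of the three.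

Compound 4, `Cc1cc(F)cc(NS(=O)(=O)c2ccc(-c3cnc(C4CC4)o3)cc2)c1`, has not yet been measured. It differs from compound 3 by fluoro in place of chloro on an aromatic carbon. Among the measured compounds shown here, this is the same kind of change as the one from compound 1 to compound 2, though not the same: in compound 1 the chloro that leaves sits ortho to a chloro group and meta to a large group, whereas in compound 3 it sits meta to a large group and meta to a methyl group. In this assay the earlier fluoro-for-chloro step was within the scatter, so the step from compound 3 to compound 4 is expected to be a 1.3-fold higher number from compound 3 to compound 4 (0.11 log units; within the scatter), resting on the step of a 1.0-fold higher number from compound 1 to compound 2 (0.01 log units; within the scatter) and on the value of compound 3 alone. Compound 4 is accordingly estimated to give 9000 nM, with a likely range from 4000 nM to 25000 nM.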

Compound 4, concentration for total growth inhibition: 7250 nM
For compound 4 the middle estimate is 1.2-fold (0.09 log units) above the measured one; measured number inside the range.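

In this assay the new step is a 1.0-fold higher number from compound 3 to compound 4 (0.01 log units; within the scatter), so fluoro in place of chloro on an aromatic carbon again gives two numbers that cannot be told apart, and the step carries over from one core to the other without a detectable difference: the same change on two cores in this assay, a 1.0-fold higher number (0.01 log units; within the scatter) from compound 1 to compound 2 and a 1.0-fold higher number (0.01 log units; within the scatter) from compound 3 to compound 4, 1.0-fold (0.01 log units) apart, within the scatter of two such steps

The larger gap between the aryl groups on the sulfonamide nitrogen also survives the change, with an 8.7-fold lower number from compound 2 to compound 4 (0.94 log units; beyond the scatter) and an 8.6-fold lower number from compound 1 to compound 4 (0.93 log units; beyond the scatter), both beyond the scatter. Among the compounds shown here, this agreement rests on only two pairs of compounds in one assay, and both steps are null, so it does not show that the change would stay this small on other cores, at other places on the ring, or in any other read-out.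

The compounds shown leave open which feature of the 3-chloro-5-methylphenyl and 3-fluoro-5-methylphenyl groups goes with their lower numbers, as the methyl group is never removed from them alone. Also open, from the compounds shown here alone, is whether a methoxy group or a nitrile in place of the chloro or fluoro would leave the number as unmoved as these two halogens do.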